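A Ring Swap on Sulfur Among Weakly Active Compounds

A few compounds are considered here, and "the series" means these few. Any claim that something is new, unique, unknown or untested is made for them only; others in the source may bear on it.

The compounds sharing one core have been measured in a functional assay on PC-3 cells (Homo sapiens) for inhibition, read by MTT assay, with a stated time of 72 h; on this read-out higher numbers stand for weaker inhibition and lower numbers for stronger inhibition. Compound 1 `CCN1CCN(c2cc(C(F)(F)F)nc(SCc3ccc(C(F)(F)F)cc3)n2)CC1` gives 27200 nM, and compound 2 `FC(F)(F)c1ccc(CSc2nc(N3CCN(c4ccccc4)CC3)cc(C(F)(F)F)n2)cc1` gives 42700 nM. Compound 3 `FC(F)(F)c1ccc(CSc2nc(Sc3ncccn3)cc(C(F)(F)F)n2)cc1` gives > 50000 nM, which is a limit and not a number. The starting point for the next step is therefore (the limit of > 50000 nM in this assay, at which 1 of the 3 values shown sits).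

Compound 4 `FC(F)(F)c1ccc(CSc2nc(Sc3nncs3)cc(C(F)(F)F)n2)cc1` differs from compound 3 in one place, with 1,3,4-thiadiazol-2-yl in place of pyrimidin-2-yl on a sulfur.

For the measured compounds named here, no measured step tests this exact swap, so only two more distant steps bear on it. Replacing ethyl with phenyl on an amine nitrogen in a ring gave a 1.6-fold higher number from compound 1 to compound 2 (0.20 log units; within the scatter). Replacing 4-ethylpiperazin-1-yl with (pyrimidin-2-yl)sulfanyl on an aromatic carbon gave an at least 1.8-fold higher number from compound 1 to compound 3 (0.26 log units; that floor lies within the scatter). Neither step shows a change beyond the scatter, although the second gives only a floor. On that basis, no step beyond the scatter is expected in this assay, in either direction. The expected size of the change is a number no higher from compound 3 to compound 4 (the limit leaves the size open). Compound 4 is estimated at 50000 nM, with an expected range from 25000 nM to 100000 nM. A result reported only as a limit would fit this expectation.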

Compound 4, half-maximal inhibitory concentration: 7880 nM
The estimate for compound 4 lay 6.3-fold (0.80 log units) above the measured number; the measured number lies below the stated range.
By their numbers in this assay, from the lowest: compound 4; then compounds 1 and 2 (each within the scatter of the next). At a limit, above all of these: compound 3.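

In this assay, for the compounds shown here, the ring carried on this sulfur clearly matters: 1,3,4-thiadiazol-2-yl in place of pyrimidin-2-yl gives an at least 6.3-fold lower number from compound 3 to compound 4 (0.80 log units; beyond the scatter), whereas the earlier steps showed no change beyond the scatter. From the compounds shown here alone, compound 3 gives > 50000 nM, which is a limit and not a number, so this step is only a floor and its true size stays open: the limit of > 50000 nM in this assay, at which 1 of the 4 values shown sits. The swap of the whole group on the aromatic carbon gives a 3.5-fold lower number from compound 1 to compound 4 (0.54 log units; beyond the scatter), so a ring linked through sulfur at this place can go with either a limit or a measured number, depending on the ring.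

With only two rings shown on this sulfur, it stays open whether the lower number follows from the five-membered ring, from its ring sulfur or from its particular arrangement of nitrogens, a question that a 1,3,4-oxadiazol-2-yl or a pyridin-2-yl group on the same sulfur could help to separate. Going by these compounds, it also stays open why the swap lowers the number, and whether an amine or a carboxylic acid on the 1,3,4-thiadiazol-2-yl ring would lower it further.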